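This account rests on a few compounds, and the source may have more. Where it says the series, first, only, none or still open, it means among the compounds named here.

Compound 1, `COc1ccc(-c2c(C#N)c(N)nc(SCc3nc(-c4ccc(Cl)cc4)sc3Cl)c2C#N)cc1`, and compound 2, `COc1ccc(-c2c(C#N)c(N)nc(SCc3csc(-c4ccc(F)cc4)n3)c2C#N)cc1`, were both tested in an assay on CHO cells for displacement of a labelled ligand from adenosine receptor A1 (Homo sapiens); on this read-out higher numbers stand for weaker inhibition and lower numbers for stronger inhibition. On that read-out compound 1 gives 88 nM, while compound 2 gives 2.3 nM. Among the two numbers recorded so far, compound 1 stands highest; its nearest neighbour is compound 2, whose number lies far enough below it to be counted as a real difference rather than scatter. The two compounds differ in more than one place, so their values alone are noted here without any claim about which change carries the gap.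

Compound 3, `COc1ccc(-c2c(C#N)c(N)nc(SCc3csc(-c4ccc(Cl)cc4)n3)c2C#N)cc1`, has not yet been measured in this assay. Compared with compound 1, the change is hydrogen in place of chloro on an aromatic carbon. Among the measured compounds shown here, no measured pair shows this single change on its own, so what follows is an expectation rather than a reading. Because compound 2 gives 2.3 nM and shares most of its structure with compound 3, compound 3 is expected to land well below compound 1, with a step of an 18-fold lower number from compound 1 to compound 3 (1.25 log units; beyond the scatter) in this assay. Compound 3 is accordingly estimated at 5 nM, within a range from 1.5 nM to 20 nM.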

Compound 3, inhibition constant: 5 nM
Compound 3: middle estimate and measured number agree at the digits printed, and the stated range covers the measured number.
By their numbers in this assay, from the lowest: compound 2; then compound 3; then compound 1.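

Exchanging the chloro on the aromatic carbon next to the ring sulfur for hydrogen gives an 18-fold lower number from compound 1 to compound 3 (1.25 log units; beyond the scatter) in this assay, which shows that this one position on the five-membered aromatic ring strongly affects the number, with chloro there the less favourable of the two groups in this pair. The second single change, chloro in place of fluoro on the phenyl group, gives a 2.2-fold higher number from compound 2 to compound 3 (0.34 log units; beyond the scatter), a modest step beyond the scatter and smaller than the one at the ring position. Nothing available explains the size of either step.

From the compounds shown here alone, only hydrogen and chloro have been seen on that ring carbon, so it remains open whether a methyl group, a bromo or an amine there would stay close to hydrogen or fall nearer to chloro. It is also open whether the step seen with the 4-chlorophenyl group would have the same size with a 4-fluorophenyl group in its place, since the compounds shown include no pair that tests this.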